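The source may report more compounds than this note shows. Statements on the series, on what has been measured and on what is new or still open speak of the compounds shown alone.

Values in an ADME assay on ZR-75-1 cells (Homo sapiens) for cytotoxicity; a lower number here means a stronger inhibitor, a higher number a weaker inhibitor:
- compound 1 `COc1ccc(-n2cnnc2-c2cc(OC)c(OC)c(OC)c2)cc1`: 522 nM
- compound 2 `COc1cc(-c2nncn2-c2ccc(N(C)C)cc2)cc(OC)c1OC`: 308 nM
- compound 3 `COc1ccc(-n2cnnc2-c2cc(OC)c(OC)c(OC)c2)cc1O`: not yet measured

Among the compounds with values here, compound 1 stands within the scatter of compound 2, the only other measured compound: a 1.7-fold lower number from compound 1 to compound 2 (0.23 log units; within the scatter). Compound 3 differs from compound 1 as follows: hydroxy in place of hydrogen on an aromatic carbon. Within the data shown here, no measured step shows this change. Among the measured compounds shown here, the one available step, a 1.7-fold lower number from compound 1 to compound 2 (0.23 log units; within the scatter), swaps methoxy for dimethylamino and bears on it only loosely. A lower number in this assay is expected, but with little support and a wide range. The estimated change is a 2.9-fold lower number from compound 1 to compound 3 (0.46 log units; beyond the scatter). For compound 3 the expected value is 180 nM, with an estimated range of 25 nM to 700 nM.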

Compound 3, half-maximal inhibitory concentration: 141 nM
Beside the measured number, compound 3's estimate is 1.3-fold (0.11 log units) above it; the range from low to high includes it.
By their numbers in this assay, from the lowest: compound 3; then compounds 2 and 1 (each within the scatter of the next).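

In this assay, within the data shown here, the step with hydroxy in place of hydrogen, on an aromatic carbon ortho to a methoxy group, is a 3.7-fold lower number from compound 1 to compound 3 (0.57 log units; beyond the scatter) and is the only step beyond the scatter. The earlier change on this ring, dimethylamino in place of methoxy, gave a 1.7-fold lower number from compound 1 to compound 2 (0.23 log units; within the scatter) and so showed no clear movement. Nothing on hand explains the shift.

The compounds shown leave open whether an amine or a fluorine on this same carbon would act as hydroxy does. They also leave open whether the hydroxy step holds with dimethylamino in place of the methoxy group.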